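The source may report more compounds than this note shows. Statements on the series, on what has been measured and on what is new or still open speak of the compounds shown alone.

Measured so far in a functional assay on MCF7 cells (Homo sapiens) for cytotoxicity; a higher number here means that more compound is needed for the effect, a lower number that less compound is needed:
compound 1 `COc1cc(Cc2nc3c(N)ncnc3n2CCO)cc(OC)c1OC` — 222000000 nM
compound 2 `CCCCn1c(Cc2cc(OC)c(OC)c(OC)c2)nc2c(N)nc(F)nc21` — 185000000 nM
compound 3 `COCCCn1c(Cc2cc(OC)c(OC)c(OC)c2)nc2c(N)nc(F)nc21` — 72600000 nM

Compound 3 gives the lowest of the three numbers in this assay; compound 2 stands nearest to it and compound 1 furthest. Compounds 1 and 2 differ from each other at more than one place, so for that pair only the two values themselves can be read. For the measured compounds named here, the single one-point step in the set is a 2.5-fold lower number from compound 2 to compound 3 (0.41 log units; beyond the scatter).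

Compound 4 `C=CCCn1c(Cc2cc(OC)c(OC)c(OC)c2)nc2c(N)nc(F)nc21` arises from compound 3 by vinyl in place of methoxymethyl on a saturated chain carbon, two bonds along the chain from an aromatic nitrogen. Going by the values given here, this largely reverses the one measured step: the methoxy group that entered from compound 2 to compound 3 is gone again, while a double bond now sits in the chain. Among the compounds with values here, no measured pair bears on the double bond, so the only guide is a 2.5-fold lower number from compound 2 to compound 3 (0.41 log units; beyond the scatter) read in reverse, pointing to a rise of roughly that size, back toward compound 2. The estimated step is a 2.2-fold higher number from compound 3 to compound 4 (0.34 log units; beyond the scatter). Compound 4 is therefore expected at 160000000 nM, within a range of 70000000 nM to 350000000 nM.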

Compound 4, half-maximal effective concentration: 102000000 nM
The estimate for compound 4 lay 1.6-fold (0.20 log units) above the measured number; the range from low to high includes it.
By their numbers in this assay, from the lowest: compounds 3, 4, 2 and 1 (each within the scatter of the next, the first and the last beyond it).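

In this assay vinyl in place of methoxymethyl on a saturated chain carbon, two bonds along the chain from an aromatic nitrogen, gives a 1.4-fold higher number from compound 3 to compound 4 (0.15 log units; within the scatter) and vinyl in place of ethyl at that place gives a 1.8-fold lower number from compound 2 to compound 4 (0.26 log units; within the scatter) with both steps inside the scatter. Compound 4 with its but-3-en-1-yl chain therefore cannot be separated from either compound 2 or compound 3, even though those two compounds lie beyond the scatter of each other. No measurement is available that accounts for these steps.

From the compounds shown here alone, whether a longer chain, a terminal amine or a carboxylic acid at this place would move the number clearly beyond the scatter remains open. Compound 1 differs from the others at more than one place, so the contribution of its hydroxyl-bearing chain also remains unresolved.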